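One Aromatic Arm Replaced by a Short Chain

The source may report more compounds than this note shows. Statements on the series, on what has been measured and on what is new or still open speak of the compounds shown alone.

Of the compounds shown here, three built on one shared core have been measured in a functional assay on MCF7 cells (Homo sapiens) for antiproliferative activity, read by sulforhodamine B assay, with a stated time of 48 h; on this read-out lower numbers stand for stronger inhibition and higher numbers for weaker inhibition. Compound 1 `NC(=O)C1=C(N)Oc2nc(Nc3ccc(S(N)(=O)=O)cc3)sc2C1c1ccc(Cl)cc1` gives 41800 nM. Compound 2 `N#CC1=C(/N=C/c2ccc(Cl)cc2)Oc2nc(Nc3ccc(S(N)(=O)=O)cc3)sc2C1c1ccc(Cl)cc1` gives 34600 nM, the lowest of the three numbers, although its gaps to the other two both fall within the usual scatter of this measurement. Compound 3 `N#CC1=C(NC(N)=O)Oc2nc(Nc3ccc(S(N)(=O)=O)cc3)sc2C1c1ccc(Cl)cc1` gives 49800 nM. Among the measured compounds shown here, the only step that changes a single place is a 1.4-fold higher number from compound 2 to compound 3 (0.16 log units; within the scatter), in which the same aromatic arm discussed below is traded for a short chain, and that step stays within the scatter. Compound 4 `N#CC1=C(NC(=O)CCl)Oc2nc(Nc3ccc(S(N)(=O)=O)cc3)sc2C1c1ccc(Cl)cc1` has not yet been measured. It differs from compound 2 by a group of 5 heavy atoms (2 carbon, 1 nitrogen, 1 oxygen, 1 chlorine; no ring) in place of a group of 9 heavy atoms (7 carbon, 1 nitrogen, 1 chlorine; one six-membered aromatic ring of carbon only), on a double-bonded ring carbon. Because a 1.4-fold higher number from compound 2 to compound 3 (0.16 log units; within the scatter) stayed within the scatter, a second replacement of that arm by a short chain is expected to leave the read-out about where compound 2 stands. The step expected is a 1.2-fold higher number from compound 2 to compound 4 (0.06 log units; within the scatter). Compound 4 is therefore expected to give 40000 nM, with a range from 20000 nM to 80000 nM.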

Compound 4, half-maximal inhibitory concentration: 43800 nM
Compound 4: the middle estimate sits 1.1-fold (0.04 log units) below what was measured; measured number inside the range.
By their numbers in this assay, from the lowest: compounds 2, 1, 4 and 3 (each within the scatter of the next).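

At this double-bonded ring carbon, a second chain, ((chloromethyl)carbonyl)amino, replaces the aromatic arm, and in this assay this gives a 1.3-fold higher number from compound 2 to compound 4 (0.10 log units; within the scatter) and stays within the scatter, so two different chains without a ring now read like the ring-bearing group. The far end of the chain can also differ: chloromethyl in place of amino on the carbonyl carbon gives a 1.1-fold lower number from compound 3 to compound 4 (0.06 log units; within the scatter) and again stays within the scatter. No measurement here offers a reason for either result.

On these data alone, whether any group at this carbon can move the number beyond the scatter remains open. A longer chain such as hexanoylamino, a saturated ring such as morpholine, or a carboxylic acid at this carbon would test that question.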